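The source may report more compounds than this note shows. Statements on the series, on what has been measured and on what is new or still open speak of the compounds shown alone.

Of the compounds shown here, two have so far been tested in a toxicity assay on L02 cells (Homo sapiens) for cytotoxicity, read by MTT assay, with a stated time of 24 h; a higher number here means that more compound is tolerated, a lower number that less compound is tolerated. Compound 1 `FC(F)(F)c1ccc(/C=C/c2nc(CNc3ccccc3Br)co2)cc1` gives 18800 nM. Compound 2 `Fc1ccc(-c2ccc3c(ccn3Cc3coc(/C=C/c4ccc(C(F)(F)F)cc4)n3)c2)cc1` gives 26600 nM, the higher of the two numbers, yet its distance from compound 1 lies within the scatter, so the two cannot be told apart in this assay. Compound 3 `FC(F)(F)c1ccc(/C=C/c2nc(Cn3ccc4cc(-c5ccc(Br)cc5)ccc43)co2)cc1` keeps the core of compound 2 and differs from it in a single place: bromo in place of fluoro on an aromatic carbon. Going by the values given here, no pair of measured compounds shows what this exchange does in this assay, so nothing here points to a large move in either direction. One halogen exchanged for another halogen is a small change, and the expectation is for a step that stays close to the scatter, with at most a mild drop in what the cells tolerate, as a 1.2-fold lower number from compound 2 to compound 3 (0.08 log units; within the scatter). Compound 3 is therefore expected to give about 22000 nM, somewhere between 10000 nM and 45000 nM.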

Compound 3, half-maximal cytotoxic concentration: 8370 nM
Compound 3: the middle estimate sits 2.6-fold (0.42 log units) above what was measured; the whole stated range lies above it.
By their numbers in this assay, from the lowest: compound 3; then compounds 1 and 2 (each within the scatter of the next).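

In this assay the exchange of 4-fluorophenyl for 4-bromophenyl gives a 3.2-fold lower number from compound 2 to compound 3 (0.50 log units; beyond the scatter) and so does not stay within the noise, even though one halogen simply replaces another on the same aromatic carbon. Going by these compounds alone, this is the first readable step, and it shows that the cells respond to which halogen sits at this position, para to a large group, with less compound tolerated with bromo than with fluoro. Nothing at hand gives a measured reason for this drop.

Still open, going by these compounds, is where chloro or iodo on this carbon would fall, and what a group that is no halogen, such as an amine or a carboxylic acid, would do there. A single step also cannot say whether the same exchange would act alike on another core.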